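The source may hold more compounds than are shown below. What is called first, only, known or untested is meant among the compounds shown, and "the series" means these compounds.

Measured so far in a functional assay on A2780 cells (Homo sapiens) for inhibition; on this read-out higher numbers stand for weaker inhibition and lower numbers for stronger inhibition:
- compound 1 `C[C@H](C(=O)Nc1cc(C2CC2)[nH]n1)c1ccc(N2CCCC2)cc1`: 220 nM
- compound 2 `C[C@H](C(=O)Nc1cc(C2CC2)[nH]n1)c1ccc(N2CCNC2=O)cc1`: 1270 nM
- compound 3 `CC(C(=O)Nc1cc(C2CC2)[nH]n1)c1ccc(N2CCC(C(N)=O)C2=O)cc1`: 5710 nM

Compound 2 sits in the middle of these three numbers, with compound 1 lower and compound 3 higher. Compound 4 `C[C@@H](C(=O)Nc1cc(C2CC2)[nH]n1)c1ccc(N2CCNC2=O)cc1` has the same atoms and bonds as compound 2: the two compounds have the same atoms and bonds and differ only in configuration as drawn: 1 of 1 stereo elements differ; a stereocentre at a saturated chain carbon is drawn S in compound 2 and R in compound 4. A stereocentre at a saturated chain carbon is drawn S in compound 2 and R in compound 4.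

Going by the values given here, no measured pair differs in configuration alone. Among the compounds with values here, the only measured step is a 5.8-fold higher number from compound 1 to compound 2 (0.76 log units; beyond the scatter), a modest change of ring group that shows how far one edit can move the number in this assay. It says nothing directly about configuration. The one weak hint is that the two lowest numbers, compound 1 at 220 nM and compound 2 at 1270 nM, both come from compounds drawn S.

A step of similar or somewhat larger size towards a higher number is therefore expected, beyond the scatter, though with wide uncertainty. The expected step is a 3.9-fold higher number from compound 2 to compound 4 (0.60 log units; beyond the scatter). The estimate for compound 4 is 5000 nM, with an expected range from 1500 nM to 20000 nM.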

Compound 4, half-maximal inhibitory concentration: 13200 nM
For compound 4 the middle estimate is 2.6-fold (0.42 log units) below the measured one; the measured number falls inside the stated range.
By their numbers in this assay, from the lowest: compound 1; then compound 2; then compound 3; then compound 4.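

The earlier compounds showed only what changing a ring group does; this pair shows that the stereocentre at the saturated chain carbon also matters in this assay, with a 10-fold higher number from compound 2 to compound 4 (1.02 log units; beyond the scatter) when that centre is drawn R rather than S. The step can be assigned to this stereocentre alone, because nothing else separates the two structures: the fact that compounds 2 and 4 differ only in the configuration as drawn

In this pair, then, the S form gives the stronger inhibition, though one pair cannot establish a general rule for the series.

From the compounds shown here alone, whether R carries a similar penalty with the pyrrolidin-1-yl group of compound 1 stays open, and compound 3, drawn without a defined configuration, cannot settle it. Also open, going by these compounds, is whether S would remain favoured with an amine or a carboxylic acid in place of the 2-oxoimidazolidin-1-yl group.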